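Chloro for hydrogen on the shared core: cytotoxicity notes

A few compounds are considered here, and "the series" means these few. Any claim that something is new, unique, unknown or untested is made for them only; others in the source may bear on it.

Three compounds of the series have been run in an ADME assay on RAW264.7 cells (Mus musculus) for cytotoxicity, read by MTT assay, with a stated time of 72 h, tested at 50 uM; a higher number here means a stronger effect of the compound at the concentration tested, a lower number a weaker effect. Compound 1 `O=C(Cn1c(=O)oc2ccccc21)Nc1cc(C(F)(F)F)ccc1Cl` gives 12.3% in this assay. Compound 2 `O=C(Cn1c(=O)oc2cc(Cl)ccc21)NCc1cccs1` gives 20.3% in this assay, and compound 3 `O=C(Cn1c(=O)oc2ccccc21)NCc1cccs1` gives 23.4% in this assay.

Compounds 3 and 2 differ in one place only: chloro in place of hydrogen on an aromatic carbon. The step of a number 3.1 percentage points lower from compound 3 to compound 2 (within the scatter) is small. Between compound 1 and compound 3 the difference in structure is not broken down here; their values differ by an amount beyond the usual scatter, compound 1 giving the lower number, while the values of compound 1 and compound 2 lie within the scatter of one another and support no ordering.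

Compound 4 `O=C(Cn1c(=O)oc2cc(Cl)ccc21)Nc1cc(C(F)(F)F)ccc1Cl` has not yet been measured. It differs from compound 1 by chloro in place of hydrogen on an aromatic carbon. The place of the change is described in the same words as for the step from compound 3 to compound 2, so this is the same change made on a different core.

Set beside the earlier step of a number 3.1 percentage points lower from compound 3 to compound 2 (within the scatter), the step of a number 1.3 percentage points lower from compound 1 to compound 4 (within the scatter) is expected to be of similar size, resting only on the one measured example of this change. Compound 4 is therefore estimated to give 11% in this assay, with the range 3% to 22% allowing for the scatter of the measurement.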

Compound 4, a percentage reported as inhibition, at one concentration (the size of the read-out at that concentration, not a potency): 1.61%
Compound 4: the middle estimate sits 9.4 percentage points above what was measured; measured number outside the range, below it.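

In this assay, chloro in place of hydrogen on an aromatic carbon now gives a number 10.7 percentage points lower from compound 1 to compound 4 (beyond the scatter), a step that can be read beyond the scatter, whereas on the other core the same change gave a number 3.1 percentage points lower from compound 3 to compound 2 (within the scatter). Set side by side, the two steps do not separate the cores: the same change on two cores in this assay, a number 3.1 percentage points lower (within the scatter) from compound 3 to compound 2 and a number 10.7 percentage points lower (beyond the scatter) from compound 1 to compound 4, 7.6 percentage points apart, within the scatter of two such steps. This supports carrying the change between these two cores with no measurable difference in the size of the step, but two pairs cannot show that the step is constant, and with only one of the two beyond the scatter, no general lowering by chloro can be claimed for the series.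

The compounds shown leave open how another group on the same aromatic carbon, such as fluoro, bromo, methoxy or an amine, would compare with chloro in this read-out. Also open, on these data alone, is whether the chloro step would hold on a third core, for instance one carrying a carboxylic acid or a longer chain on the amide nitrogen in place of the groups present in compound 1 and compound 3.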